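The source may hold more compounds than are shown below. What is called first, only, known or untested is meant among the compounds shown, and "the series" means these compounds.

Within the data shown here, in a functional assay on PCa 2b cells (Homo sapiens) for cytotoxicity, read by MTT assay, with a stated time of 72 h (a higher number here means a weaker inhibitor, a lower number a stronger inhibitor), compound 1 (`CC1=C(/C=C/C(=O)/C=C/c2cccc(C(F)(F)F)c2)C(C)(C)CCC1O`) gives 2600 nM, the only number available for this small group of compounds sharing one core. Compound 2 (`CC1=C(/C=C/C(=O)/C=C/c2ccccc2F)C(C)(C)CCC1O`) has no single number, and its entry reads "not determined" (no result reported). Compound 3 (`CC1=C(/C=C/C(=O)/C=C/c2c(F)cccc2C(F)(F)F)C(C)(C)CCC1O`) is in the same position, with an entry of "not determined" (no result reported). Compound 2 therefore has no place on the potency scale and gives no starting value from which a step could be counted.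

Compound 4 (`CC1=C(/C=C/C(=O)/C=C/c2cccc(C)c2)C(C)(C)CCC1O`) has yet to be measured in this assay. It differs from compound 2 by a single exchange, 3-methylphenyl in place of 2-fluorophenyl on a double-bonded chain carbon bound to a double-bonded chain carbon. Among the measured compounds shown here, no pair of measured compounds shows what a change of this kind does, so the data offer no size or direction for it. For the measured compounds named here, the only anchor is compound 1 at 2600 nM, and the expectation is that compound 4 will land within the usual scatter of that value, with no shift in either direction beyond it, though the uncertainty is wide. For compound 4 the estimated value is 3000 nM, with an expected range from 1100 nM to 8000 nM.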

Compound 4, half-maximal inhibitory concentration: 19000 nM
For compound 4 the middle estimate is 6.3-fold (0.80 log units) below the measured one; measured number above the stated range.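

In this assay, methyl in place of trifluoromethyl on an aromatic carbon brings a 7.3-fold higher number from compound 1 to compound 4 (0.86 log units; beyond the scatter), a modest step but one beyond the scatter. Among these compounds, this makes compound 4 the weaker inhibitor of the pair and gives the first size and direction for a change on this aromatic ring, which the earlier compounds could not provide with only one number among them. Nothing measured here speaks to why the exchange has this effect, so the pair records only the size and direction of the step.

The steps that involve compound 2 or compound 3 cannot be read, which leaves the 2-fluorophenyl of compound 2 unplaced against the 3-methylphenyl of compound 4, and one pair cannot show whether the same step would hold with other ring patterns. Among the compounds shown here, also open is where an amine, a carboxylic acid or a longer chain on that aromatic carbon would fall relative to compound 1 and compound 4, since trifluoromethyl and methyl are the only two groups there that can be compared.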